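This account rests on a few compounds, and the source may have more. Where it says the series, first, only, none or still open, it means among the compounds named here.

Measured in a functional assay on HCC827 cells (Homo sapiens) for antiproliferative activity, read by MTT assay, with a stated time of 72 h; on this read-out lower numbers stand for stronger inhibition and higher numbers for weaker inhibition:
- compound 1 `CN1CCN(c2ccc(Nc3ncc4nc(Nc5ccc(F)cc5)n(-c5cccc(NC(=O)CO)c5)c4n3)cc2)CC1`: 7.5 nM
- compound 2 `CN1CCN(c2ccc(Nc3ncc4nc(Nc5ccc(F)cc5)n([C@@H]5CCN(S(=O)(=O)C6CC6)C5)c4n3)cc2)CC1`: 2.5 nM
- compound 3 `CN1CCN(c2ccc(Nc3ncc4nc(Nc5ccc(F)cc5)n([C@H]5CCN(C(=O)OC(C)(C)C)C5)c4n3)cc2)CC1`: 580 nM

Of these three, compound 3 has the highest number, at 580 nM, and so the weakest inhibition. The next compound, compound 4 `CN1CCN(c2ccc(Nc3ncc4nc(Nc5ccc(F)cc5)n(CCNS(=O)(=O)C5CC5)c4n3)cc2)CC1`, has not yet been measured. In it, 2-((cyclopropylsulfonyl)amino)ethyl stands in place of 1-(tert-butoxycarbonyl)pyrrolidin-3-yl on an aromatic nitrogen: 2-((cyclopropylsulfonyl)amino)ethyl in place of 1-(tert-butoxycarbonyl)pyrrolidin-3-yl on an aromatic nitrogen.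

The closest guide is a 230-fold higher number from compound 2 to compound 3 (2.37 log units; beyond the scatter), a large rise in the number that comes with the same tert-butoxycarbonyl group, starting from a cyclopropylsulfonyl compound. A second large rise, a 77-fold higher number from compound 1 to compound 3 (1.89 log units; beyond the scatter), shows that compound 1 also lies far below compound 3 with a quite different group at this place. The step of a 3.0-fold lower number from compound 1 to compound 2 (0.48 log units; beyond the scatter) is only modest by comparison. Going by the values given here, no measured compound carries the open ethyl chain of compound 4, so a full return to the level of compound 2 is uncertain.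

A large fall is therefore expected, estimated as a 48-fold lower number from compound 3 to compound 4 (1.68 log units; beyond the scatter). For compound 4 the estimated value is 12 nM, with an expected range of 3 nM to 60 nM.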

Compound 4, half-maximal inhibitory concentration: 50 nM
For compound 4 the middle estimate is 4.2-fold (0.62 log units) below the measured one; the measured number falls inside the stated range.
By their numbers in this assay, from the lowest: compound 2; then compound 1; then compound 4; then compound 3.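

In this assay, a cyclopropylsulfonyl group on an open chain at this aromatic nitrogen still beats the tert-butoxycarbonyl compound (a 12-fold lower number from compound 3 to compound 4 (1.06 log units; beyond the scatter)), so the pyrrolidine ring is not needed for a large part of that gain. The ring still counts, however: the same sulfonyl group held on the pyrrolidine gives a clearly lower number than the open chain (a 20-fold higher number from compound 2 to compound 4 (1.30 log units; beyond the scatter)), and the 3-(((hydroxymethyl)carbonyl)amino)phenyl group also gives a lower number, though by a smaller margin (a 6.7-fold higher number from compound 1 to compound 4 (0.82 log units; beyond the scatter)). Nothing available here explains these differences.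

As far as these compounds go, it remains open whether a longer chain carrying the same sulfonamide would move the number towards that of compound 2, or whether a six-membered piperidine ring would match the pyrrolidine. Also unknown is how much the cyclopropyl itself contributes compared with a simple methyl on the sulfonyl group.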